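This account rests on a few compounds, and the source may have more. Where it says the series, first, only, none or still open, it means among the compounds named here.

In a functional assay on MDA-MB-231 cells (Homo sapiens) for antiproliferative activity, read by XTT assay, with a stated time of 72 h (a lower number here means a stronger inhibitor, a higher number a weaker inhibitor), the measured compounds read as follows.
compound 1 `COc1ccc(-c2cc3ccccc3nc2/C=C/C(=O)c2ccccc2)cc1` gives 860 nM
compound 2 `COc1ccc(-c2cc3ccccc3nc2/C=C/C(=O)c2ccc(F)cc2)cc1` gives 830 nM
compound 3 `COc1ccc(C(=O)/C=C/c2nc3ccccc3cc2-c2ccc(OC)cc2)cc1` gives 7540 nM

Compound 3 has the highest number of the three, at 7540 nM, and so is the weakest inhibitor measured here. The next structure is compound 4 `COc1ccc(-c2cc3ccccc3nc2/C=C/C(=O)c2c(OC)cccc2OC)cc1`, with 2,6-dimethoxyphenyl in place of 4-methoxyphenyl on a carbonyl carbon.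

Within the data shown here, two measured steps touch the same aryl group and point the same way. One is an 8.8-fold higher number from compound 1 to compound 3 (0.94 log units; beyond the scatter), with methoxy in place of hydrogen, and the other is a 9.1-fold higher number from compound 2 to compound 3 (0.96 log units; beyond the scatter), with methoxy in place of fluoro. The fluoro swap alone, a 1.0-fold lower number from compound 1 to compound 2 (0.02 log units; within the scatter), gives no measurable change. Compound 4 loses the 4-methoxyphenyl group of compound 3, which suggests some recovery towards compound 1 and compound 2. However, no measured compound carries 2,6-dimethoxyphenyl, and compound 4 still holds methoxy groups, so full recovery is not assumed.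

A modest fall in the number is expected, and the expected step is a 3.0-fold lower number from compound 3 to compound 4 (0.48 log units; beyond the scatter) in this assay, with real uncertainty about its size. Compound 4 is estimated at 2500 nM and expected to fall between 700 nM and 9000 nM in this assay.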

Compound 4, half-maximal inhibitory concentration: 5630 nM
Estimate against measurement, compound 4: 2.3-fold (0.35 log units) below, within the range that was stated.
By their numbers in this assay, from the lowest: compounds 2 and 1 (each within the scatter of the next); then compounds 4 and 3 (each within the scatter of the next).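

In this assay, 2,6-dimethoxyphenyl in place of 4-methoxyphenyl on the carbonyl carbon gives a 1.3-fold lower number from compound 3 to compound 4 (0.13 log units; within the scatter) and so does not separate these two methoxy-bearing aryl groups. Against the other two aryl groups, 2,6-dimethoxyphenyl gives a 6.5-fold higher number from compound 1 to compound 4 (0.82 log units; beyond the scatter) and a 6.8-fold higher number from compound 2 to compound 4 (0.83 log units; beyond the scatter) in place of phenyl and 4-fluorophenyl, so the shift seen earlier with 4-methoxyphenyl is not limited to that one group. Across these four compounds, both methoxy-bearing aryl groups read higher than phenyl and 4-fluorophenyl, no compound goes against this, and no supporting data are available to explain it.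

The compounds shown leave open whether a hydroxy group or an amine on this aryl ring would read with compound 3 and compound 4 or with compound 1 and compound 2. Also open, on these data alone, is how a pyridine ring in place of the aryl group on the carbonyl carbon would read in this assay and whether the pattern would hold there.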